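The compounds below may be only part of what the source reports. "The series", "measured", "known", "first", "only" and "open" are said of these compounds alone.

Within the data shown here, in a functional assay on MGC-803 cells (Homo sapiens) for antiproliferative activity, read by MTT assay, with a stated time of 48 h (a higher number here means a weaker inhibitor, a lower number a stronger inhibitor), compound 2 `O=C(Nc1cccc(CNc2nccnc2Cl)c1)Nc1ccc(Cl)c(Cl)c1` gives 4970 nM, the lowest of the two numbers measured so far, while compound 1 `O=C(Nc1ccccc1)Nc1cccc(CNc2nccnc2Cl)c1` gives 16300 nM. Among the measured compounds shown here, the one measured step, a 3.3-fold lower number from compound 1 to compound 2 (0.52 log units; beyond the scatter), is the only guide for the next change. Compound 3 `Cc1cccc(NC(=O)Nc2cccc(CNc3nccnc3Cl)c2)c1` differs from compound 2 by 3-methylphenyl in place of 3,4-dichlorophenyl on an amide-type nitrogen. Because a 3.3-fold lower number from compound 1 to compound 2 (0.52 log units; beyond the scatter) came with the chlorines that 3-methylphenyl lacks, part of that drop is expected to reverse, so a modest rise is anticipated, a 1.8-fold higher number from compound 2 to compound 3 (0.26 log units; within the scatter). Compound 3 is therefore estimated at 9000 nM, within a range from 4000 nM to 20000 nM.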

Compound 3, half-maximal inhibitory concentration: 14600 nM
Beside the measured number, compound 3's estimate is 1.6-fold (0.21 log units) below it; measured number inside the range.
By their numbers in this assay, from the lowest: compound 2; then compounds 3 and 1 (each within the scatter of the next).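

In this assay the lower number seen with 3,4-dichlorophenyl on this amide-type nitrogen does not carry over to 3-methylphenyl (a 2.9-fold higher number from compound 2 to compound 3 (0.47 log units; beyond the scatter)). Set against the plain phenyl, the added methyl stays within the scatter (a 1.1-fold lower number from compound 1 to compound 3 (0.05 log units; within the scatter)), so on this ring it cannot be told apart from hydrogen. No measurement available here explains the difference between the chlorines and the methyl. Still open, on these data alone, is whether one chlorine alone would give the lower number, and how a methoxy or a carboxylic acid on this ring would read.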